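Aryl substituent changes on the shared core

The source may hold more compounds than are shown below. What is called first, only, known or untested is meant among the compounds shown, and "the series" means these compounds.

Compound 1 `COc1ccc(-c2cc3nccc(-c4cc(OC)c(OC)c(OC)c4)n3n2)cc1[N+](=O)[O-]`: in a functional assay on A549 cells (Homo sapiens) for inhibition, read by CCK-8 assay, with a stated time of 48 h (on this read-out higher numbers stand for weaker inhibition and lower numbers for stronger inhibition), compound 1 gives only a limit, > 10000 nM.
Compound 2 `COc1ccc(-c2cc3nccc(-c4cc(OC)c(OC)c(OC)c4)n3n2)cc1F`: in this assay compound 2 gives 545 nM.

Among the measured compounds shown here, compound 2 holds the only number in this assay; the other value shown is a limit (the limit of > 10000 nM in this assay, at which 1 of the 2 values shown sits). For the measured compounds named here, the single measured step, an at least 18-fold lower number from compound 1 to compound 2 (1.26 log units; beyond the scatter), concerns fluoro in place of nitro on an aromatic carbon and is large.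

Compound 3 `COc1cc(-c2ccnc3cc(-c4ccc(F)cc4)nn23)cc(OC)c1OC` differs from compound 2 by 4-fluorophenyl in place of 3-fluoro-4-methoxyphenyl on an aromatic carbon. The change sits on an aromatic carbon of a five-membered aromatic ring with two nitrogens, part of a fused system of two rings, next to the ring nitrogen. The measured step from compound 1 to compound 2 does not touch this position or this kind of exchange, so it offers no direct guide; the methoxy group is lost and the fluoro is kept on the ring. With no step of the same kind shown, the expected movement is small, and the estimated step of a 1.5-fold higher number from compound 2 to compound 3 (0.17 log units; within the scatter) is likely within the scatter. Compound 3 is therefore expected to give about 800 nM, with a range from 250 nM to 2500 nM.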

Compound 3, half-maximal inhibitory concentration: 3800 nM
For compound 3 the middle estimate is 4.8-fold (0.68 log units) below the measured one; measured number outside the range, above it.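

In this assay the exchange of 3-fluoro-4-methoxyphenyl for 4-fluorophenyl gives a 7.0-fold higher number from compound 2 to compound 3 (0.84 log units; beyond the scatter) and so shows that this aryl group on the five-membered aromatic ring responds to more than the nitro and fluoro exchange seen earlier. Both groups carry a fluoro, yet 3-fluoro-4-methoxyphenyl gives the lower number, so a fluoro on this aryl ring does not alone set the value; the change removes the methoxy group and also places the fluoro differently, and the step cannot be assigned to either part. The data shown offer no measured property that would explain this step.

The compounds shown leave open whether the methoxy group or the place of the fluoro carries the step, a question that 4-methoxyphenyl and 3-fluorophenyl would separate. Also open, from the compounds shown here alone, are the effect of an amine or a carboxylic acid on this aryl ring and of any change to the other aryl group, which is the same in compound 1, compound 2 and compound 3.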